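From Ethyl to Bromo: Expecting a Weaker Inhibitor

A few compounds are considered here, and "the series" means these few. Any claim that something is new, unique, unknown or untested is made for them only; others in the source may bear on it.

Among the compounds with values here, compound 3 `CCc1ccc(NCC(=O)Nn2c(-c3ccccc3)nc3ccccc3c2=O)cc1` holds the second highest of the three numbers measured so far. In a functional assay on A549 cells (Homo sapiens) for cytotoxicity, read by MTT assay, with a stated time of 4 h (a lower number here means a stronger inhibitor, a higher number a weaker inhibitor), compound 3 gives 2100 nM. Its nearest neighbour is compound 2 `O=C1N=C(NN2Cc3ccccc3N=C2c2ccccc2)S/C1=C/c1ccccc1`, which gives 720 nM in this assay, and the furthest is compound 1 `O=C1N=C(NN2Cc3ccccc3N=C2c2ccccc2)S/C1=C/c1ccc(Br)cc1`, which gives 21300 nM; compound 3 thus sits much closer to compound 2 than to compound 1.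

Compound 4 `O=C(CNc1ccc(Br)cc1)Nn1c(-c2ccccc2)nc2ccccc2c1=O` differs from compound 3 in a single place: bromo in place of ethyl on an aromatic carbon. Within the data shown here, only one measured step touches this change, a 30-fold lower number from compound 1 to compound 2 (1.47 log units; beyond the scatter), in which taking bromo away went with a far lower number, so a bromo on the shared core of compounds 1 and 2 went with a weaker inhibitor. That step is not the same change: there hydrogen took the place of bromo, whereas here bromo takes the place of ethyl, and compounds 1 and 2 carry a different core from compound 3. The evidence nonetheless points one way, so compound 4 is expected to give a higher number than compound 3, a 2.4-fold higher number from compound 3 to compound 4 (0.38 log units; beyond the scatter), a step of moderate size with wide uncertainty. The estimate for compound 4 in this assay is 5000 nM, with a range from 1500 nM to 20000 nM.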

Compound 4, half-maximal inhibitory concentration: 25000 nM
Compound 4: middle estimate off by 5.0-fold (0.70 log units), on the low side, and the stated range ends below it.
By their numbers in this assay, from the lowest: compound 2; then compound 3; then compounds 1 and 4 (each within the scatter of the next).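

In this assay, the change from 4-ethylphenyl to 4-bromophenyl gives a 12-fold higher number from compound 3 to compound 4 (1.08 log units; beyond the scatter), so this place on the ring strongly affects the read-out on this core, even though the swap replaces only ethyl with a single bromine atom. The earlier step set bromo against hydrogen on another core, whereas this one sets bromo against ethyl, and in both of these single-change pairs the bromo compound has the higher number, with no pair shown going against this. The data offer no measured explanation for the size or direction of this step.

As far as these compounds go, it remains open how a plain hydrogen at this place on the core of compound 3 would compare, and so whether the large step reflects mainly the loss of ethyl or the arrival of bromo. Also open, from the compounds shown here alone, is where a chloro, a methoxy, an amine, a carboxylic acid or a longer chain such as propyl would fall at this place on the same core.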